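Piperidine Amide in Place of Aminomethylamide on Shared Core

The compounds below may be only part of what the source reports. "The series", "measured", "known", "first", "only" and "open" are said of these compounds alone.

Measured compounds:
compound 1, `CC(C)(C)c1ccc(C(=O)N2CCC3(CC2)C(=O)N(CC(=O)NCN)CN3c2ccccc2)cc1`, 26500 nM
compound 2, `CC(C)(C)OC(=O)NC1CCCN(C(=O)CN2CN(c3ccccc3)C3(CCN(C(=O)c4ccc(C(C)(C)C)cc4)CC3)C2=O)C1`, 4200 nM
compound 3, `NC(=O)C1CCCN(C(=O)CN2CN(c3ccccc3)C3(CCN(C(=O)c4ccc(C5CCCCC5)cc4)CC3)C2=O)C1`, 3100 nM

Three compounds built on a shared core were tested in an assay on HEK293 cells for displacement of a labelled ligand from NPC1-like intracellular cholesterol transporter 1 (Homo sapiens); on this read-out lower numbers stand for stronger inhibition and higher numbers for weaker inhibition. Compound 1 gives 26500 nM, the highest of the three numbers. Its nearest neighbour is compound 2, whose number is lower by a margin beyond the scatter; the furthest is compound 3, lower still and also beyond the scatter. Both compound 2 and compound 3 carry a substituted piperidine amide where compound 1 carries an open-chain (aminomethyl)amino group.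

Compound 4, `CC(C)(C)c1ccc(C(=O)N2CCC3(CC2)C(=O)N(CC(=O)N2CCCCC2CO)CN3c2ccccc2)cc1`, has not yet been measured in this assay. It differs from compound 1 in one place: 2-(hydroxymethyl)piperidin-1-yl in place of (aminomethyl)amino on a carbonyl carbon. Among the compounds with values here, since no pair of measured compounds differs in exactly this way, the size of the step cannot be read directly. Compound 2 and compound 3 show that piperidine amides at this carbonyl give lower numbers than compound 1, so a lower number is expected for compound 4 as well. The estimated step of a 5.3-fold lower number from compound 1 to compound 4 (0.72 log units; beyond the scatter) is expected to lie beyond the scatter. For compound 4 the expected value in this assay is 5000 nM, with a range from 1500 nM to 16000 nM.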

Compound 4, half-maximal inhibitory concentration: 11800 nM
Compound 4: middle estimate off by 2.4-fold (0.37 log units), on the low side, within the range that was stated.
By their numbers in this assay, from the lowest: compounds 3 and 2 (each within the scatter of the next); then compound 4; then compound 1.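

In this assay, within the data shown here, this is the first change at this carbonyl carbon measured on its own with the rest of compound 1 held constant, and it gives a 2.2-fold lower number from compound 1 to compound 4 (0.35 log units; beyond the scatter). The step is modest but beyond the scatter, so a group of 8 heavy atoms with a six-membered non-aromatic ring can replace the open-chain (aminomethyl)amino group of 3 heavy atoms here without raising the number. Nothing given here accounts for the size or direction of this step.

The compounds shown leave open whether the ring alone or its hydroxymethyl group carries the step, a question that plain piperidin-1-yl on the same carbonyl carbon would address. They also leave open how a carboxylic acid or a primary amine in place of that hydroxymethyl group would read.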